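This account rests on a few compounds, and the source may have more. Where it says the series, first, only, none or still open, it means among the compounds named here.

In a functional assay on MDA-MB-453 cells (Homo sapiens) for cytotoxicity, read by MTT assay, with a stated time of 48 h (a lower number here means a stronger inhibitor, a higher number a weaker inhibitor), compound 1 (`COc1cc(C#N)ccc1OCc1nnc(-c2ccccc2)o1`) gives 40200 nM and compound 2 (`N#Cc1ccc(OCc2nnc(-c3ccc(F)cc3)o2)cc1F`) gives 25100 nM and these two values lie within the usual scatter of each other. Compound 3 (`c1ccc(-c2nnc(COc3ccc(-c4nnco4)cc3)o2)cc1`) gives > 50000 nM in this assay and this is a limit of the assay, not a number. For the measured compounds named here, compound 3 is thus the one compound resting on the limit of > 50000 nM in this assay, at which 1 of the 3 values shown sits, and its true position is unknown.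

Compound 4 (`Fc1ccc(-c2nnc(COc3ccc(-c4nnco4)cc3)o2)cc1`) differs from compound 3 in one place. The change is fluoro in place of hydrogen on an aromatic carbon and it turns phenyl into 4-fluorophenyl, with fluoro in place of hydrogen on an aromatic carbon. Going by the values given here, no measured pair shows this change alone. Compound 1 carries a phenyl and gives 40200 nM while compound 2 carries a 4-fluorophenyl and gives 25100 nM but those two also differ elsewhere, so they offer only a weak hint. In this assay the expected change is therefore small and leans toward stronger inhibition, an estimated at least 1.2-fold lower number from compound 3 to compound 4 (0.09 log units; that floor lies within the scatter) that stays close to the usual scatter. The value expected for compound 4 is 40000 nM with an estimated range from 20000 nM to 60000 nM and the assay may again report only a limit.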

Compound 4, half-maximal inhibitory concentration: 38200 nM
The estimate for compound 4 lay 1.0-fold (0.02 log units) above the measured number, and the stated range covers the measured number.
By their numbers in this assay, from the lowest: compounds 2, 4 and 1 (each within the scatter of the next). At a limit, above all of these: compound 3.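

For the compounds shown here, compound 3 and compound 4 form the first pair in which phenyl and 4-fluorophenyl are the only difference, so in this assay this change can be read on its own, as an at least 1.3-fold lower number from compound 3 to compound 4 (0.11 log units; that floor lies within the scatter). With fluoro on an aromatic carbon, para to a large group, compound 4 gives a real number of 38200 nM, so this compound provides a measured value on the shared core. The true size of the step remains unknown, and only its floor can be stated, because compound 3 gives > 50000 nM, which is a limit of the assay and not a number: the limit of > 50000 nM in this assay, at which 1 of the 4 values shown sits.

The compounds shown leave open whether a chlorine atom, an amine or a carboxylic acid at this same position would give a clearly different number from 4-fluorophenyl. Going by these compounds alone, they also leave open whether fluoro in place of hydrogen would give a similar step on the core of compound 1, where no pair with only this difference is available.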